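The source may hold more compounds than are shown below. What is called first, only, known or untested is meant among the compounds shown, and "the series" means these compounds.

Of the compounds shown here, two have so far been measured in a physicochemical assay for lipophilicity, at pH 7.4; on this read-out higher numbers stand for higher lipophilicity and lower numbers for lower lipophilicity. Compound 1, with the structure `CS(=O)(=O)NC(=O)c1cc(Cl)c(OCC2CCCCC2)cc1F`, gives 1.4 in this assay. Compound 2, with the structure `CC1(COc2cc(F)c(C(=O)NS(=O)(=O)C3CC3)cc2C2CC2)CCC2(CC1)CC2`, gives 2.1 in this assay. Of these two numbers, compound 1 holds the lower one; compound 2 stands higher by a gap that lies beyond the usual scatter of repeated measurements. The two compounds differ from each other in several places at once, so the gap between them cannot be tied to any single part of the structure.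

Compound 3, with the structure `CS(=O)(=O)NC(=O)c1cc(Cl)c(OCC2CCCC2)cc1F`, has not yet been measured. It differs from compound 1 in one place only: cyclopentyl in place of cyclohexyl on a saturated chain carbon bound to an oxygen on an aromatic ring. The entering ring is one carbon smaller than the leaving one, and the rest of the molecule is unchanged. Going by the values given here, no measured pair in this set shows this particular change, so the expectation rests on the size of the change itself. The step from compound 1 to compound 3 is expected to be a number 0.40 log units lower from compound 1 to compound 3 (beyond the scatter), a modest downward move, close to the edge of the scatter. Compound 3 is therefore estimated to give about 1 in this assay, with a likely range from 0.6 to 1.4.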

Compound 3, distribution coefficient: 1.1
For compound 3 the middle estimate is 0.10 log units below the measured one, within the range that was stated.
By their numbers in this assay, from the lowest: compounds 3 and 1 (each within the scatter of the next); then compound 2.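

Cyclopentyl in place of cyclohexyl on a saturated chain carbon bound to an oxygen on an aromatic ring gives, in this assay, a number 0.30 log units lower from compound 1 to compound 3 (within the scatter), and this is the first step in the set that can be tied to a single place in the structure. Where compound 1 and compound 2 differ in several places at once, this pair isolates one ring at one position, and the ring can lose one carbon without a difference that stands clear of the ordinary spread of repeated measurements in this assay. One pair cannot establish a rule for this position, and no separate measurement is available to explain the step.

From the compounds shown here alone, what remains open is how far this position can be changed before the read-out clearly moves, for instance with an open hexyl chain, a ring containing an amine, or a carboxylic acid at the same place. Going by these compounds, it also remains open whether the same change from cyclohexyl to cyclopentyl would give a similar step on another core, such as the core of compound 2.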